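The source may report more compounds than this note shows. Statements on the series, on what has been measured and on what is new or still open speak of the compounds shown alone.

Measured in a functional assay on PC-3 cells (Homo sapiens) for inhibition, read by MTT assay, with a stated time of 48 h, tested at 10 uM; a lower number here means less inhibition of growth, a higher number more inhibition of growth at the concentration tested:
- compound 1 `COc1ccc(COc2cc(O)c3c(=O)cc(C)oc3c2[C@H]2CCN(C)C[C@H]2O)cc1`: 35%
- compound 2 `CCN(CC)Cc1c(O)c([C@H]2CCN(C)C[C@H]2O)c2oc(C)cc(=O)c2c1O`: 2%

Only these two compounds have been measured in this assay, and they differ in more than one place. Compound 2 stands lowest of the pair: compound 2 gives 2%, while compound 1 gives 35%, a gap beyond the scatter. The next compound to be measured is compound 3 `Cc1cc(=O)c2c(O)c(CN3CC(O)CC3C(=O)O)c(O)c([C@H]3CCN(C)C[C@H]3O)c2o1`, which departs from compound 2 at a single place. The change is 2-carboxy-4-hydroxypyrrolidin-1-yl in place of diethylamino on a saturated chain carbon bound to an aromatic carbon; in words, 2-carboxy-4-hydroxypyrrolidin-1-yl stands in place of diethylamino on a saturated chain carbon bound to an aromatic carbon.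

Among the compounds with values here, no measured pair shows what a change at this place does, so the expectation rests on little. With compound 2 at 2%, there is hardly any room for a further fall, and nothing measured points to a rise. The expected outcome is a number 4 percentage points higher from compound 2 to compound 3 (within the scatter), a small upward move that stays within the scatter. For compound 3 the estimated value is 6%, with an expected range from 0% to 18%.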

Compound 3, percent growth inhibition at one concentration: 0%
Compound 3: the middle estimate sits 6 percentage points above what was measured, and the stated range covers the measured number.
By their numbers in this assay, from the lowest: compounds 3 and 2 (each within the scatter of the next); then compound 1.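

In this assay, within the data shown here, the first step that can be read at this place, on a saturated chain carbon bound to an aromatic carbon, is a number 2 percentage points lower from compound 2 to compound 3 (within the scatter), so 2-carboxy-4-hydroxypyrrolidin-1-yl and diethylamino cannot be told apart here. Although the entering group brings one five-membered non-aromatic ring and 9 heavy atoms in place of an open group of 5, compound 2 at 2% and compound 3 at 0% both remain close to the bottom of the scale, well short of the reading for compound 1, which differs from them in more than one place; with values this low, the step shows no gain but could hardly reveal any further loss. Nothing measured here explains why these two compounds read alike.

The compounds shown leave open whether plain pyrrolidin-1-yl, or the same ring carrying only the carboxylic acid or only the hydroxyl, would read any differently from the group in compound 3. They also leave open whether another amine at this place, such as morpholine or piperidine, would lift the number clear of the scatter.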